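This account rests on a few compounds, and the source may have more. Where it says the series, first, only, none or still open, it means among the compounds named here.

Measured so far:
- compound 1 `Cn1c(-c2ccc(NC(=O)CSc3nc4cc(Cl)ccc4o3)cc2)nc(-c2ccccc2)c1-c1ccccc1`: 59.7%
- compound 2 `CN(C)/C=C/N1CCN(CC(=O)Nc2ccc(-c3nc(-c4ccccc4)c(-c4ccccc4)n3C)cc2)CC1`: 25.8%

Both compounds were tested in a functional assay on MCF7 cells (Homo sapiens) for cytotoxicity, read by MTT assay, with a stated time of 24 h, tested at 32 ug/mL; on this read-out lower numbers stand for a weaker effect and higher numbers for a stronger effect at the one concentration tested. Within the data shown here, compound 2 stands lowest of the two numbers, and the only step recorded, a number 33.9 percentage points lower from compound 1 to compound 2 (beyond the scatter), is a large fall that came from putting 4-(2-(dimethylamino)ethenyl)piperazin-1-yl in place of (5-chloro-1,3-benzoxazol-2-yl)sulfanyl on a saturated chain carbon bound to a carbonyl carbon.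

Compound 3 `Cc1ccc(CN2CCN(CC(=O)Nc3ccc(-c4nc(-c5ccccc5)c(-c5ccccc5)n4C)cc3)CC2)cc1` is not yet measured. It differs from compound 2 as follows: 4-methylbenzyl in place of 2-(dimethylamino)ethenyl on an amine nitrogen in a ring. Among the measured compounds shown here, this change sits on an amine nitrogen in a ring of a six-membered non-aromatic ring with 2 nitrogen, a part of the molecule that neither measured compound varies, so no recorded step bears directly on it. For the measured compounds named here, the one step known concerns a different position and gives no guide to the size or direction of this change. The expectation for this assay is therefore a step of uncertain direction, a number 7.2 percentage points higher from compound 2 to compound 3 (within the scatter), with a wide range. Compound 3 is estimated at 33%, between 15% and 55%.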

Compound 3, a percentage reported as activity, at one concentration (the size of the read-out at that concentration, not a potency): 31.5%
The estimate for compound 3 lay 1.5 percentage points above the measured number, and the stated range covers the measured number.
By their numbers in this assay, from the lowest: compounds 2 and 3 (each within the scatter of the next); then compound 1.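

In this assay, putting 4-methylbenzyl in place of 2-(dimethylamino)ethenyl on an amine nitrogen in a ring gives a number 5.7 percentage points higher from compound 2 to compound 3 (within the scatter), so this read-out does not separate the two groups. Among these compounds, this pair is the first look at this position, and it shows that an open chain with a double bond and a larger all-carbon group holding a six-membered aromatic ring give numbers that cannot be told apart at the one concentration tested, even though the two groups share little beyond their point of attachment. Nothing measured here offers a reason for this result.

From the compounds shown here alone, with only these two groups at this nitrogen, it remains open whether any group placed there would give a number beyond the scatter of compound 2 and compound 3, for instance a bare hydrogen, a small methyl, an acetyl or a benzyl carrying a carboxylic acid. A single concentration also leaves open whether compound 2 and compound 3 would still match at other concentrations in the same cells.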